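The source may hold more compounds than are shown below. What is called first, only, known or untested is meant among the compounds shown, and "the series" means these compounds.

Measured so far:
- compound 1, `O=C(CN1CCC(c2cccc[n+]2[O-])CC1)Nc1cccc(Cl)c1`: 62 nM
- compound 2, `Cc1cccc(C(=O)NCN2CCC(c3ccccn3)CC2)c1`: 9 nM
- compound 3, `Cc1ccc(C(=O)NCN2CCC(c3cccc[n+]3[O-])CC2)cc1C`: 38 nM

All three were tested in a functional assay on HEK293 cells for agonist activity at D(4) dopamine receptor (Homo sapiens), read by FLIPR; on this read-out lower numbers stand for an effect already at smaller amounts and higher numbers for an effect only at larger amounts of compound. Compound 1 gives the highest of the three numbers. Compound 3 sits close to it, and the gap between the two is within the usual scatter of repeated measurements, so no order between them can be read. Compound 2 gives a clearly lower number, beyond the scatter, and so acts at smaller amounts than compound 1.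

Compound 4, `Cc1cc(NC(=O)CN2CCC(c3cccc[n+]3[O-])CC2)ccc1F`, has not yet been measured. It differs from compound 1 in one place: 4-fluoro-3-methylphenyl in place of 3-chlorophenyl on an amide-type nitrogen. The measured compounds differ from one another in several places at once, so none of them isolates what such a swap does in this assay. The change is modest, and no step beyond the scatter is expected in either direction. The expected step of a 1.2-fold lower number from compound 1 to compound 4 (0.09 log units; within the scatter) reflects this. In this assay compound 4 is estimated at 50 nM, with a range from 20 nM to 150 nM.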

Compound 4, half-maximal effective concentration: 18 nM
The estimate for compound 4 lay 2.8-fold (0.44 log units) above the measured number; measured number below the stated range.
By their numbers in this assay, from the lowest: compounds 2 and 4 (each within the scatter of the next); then compounds 3 and 1 (each within the scatter of the next).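

The aryl group on the amide-type nitrogen matters for this series: in this assay, 4-fluoro-3-methylphenyl in place of 3-chlorophenyl gives a 3.4-fold lower number from compound 1 to compound 4 (0.54 log units; beyond the scatter). Among these compounds, this pair is the first to isolate a single change, as the earlier compounds differed from one another in several places at once. Both groups are six-membered aromatic rings of carbon only with no net charge, so a swap that keeps those features can still shift the concentration needed for an effect, though no measurement here explains why.

This one pair cannot separate the loss of the chlorine from the arrival of the fluorine and the methyl group. Going by these compounds, how a methoxy group or a nitrile on this ring would compare, and whether the step carries over to other cores, remains open.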